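Amide cap variation around compound 1

This account rests on a few compounds, and the source may have more. Where it says the series, first, only, none or still open, it means among the compounds named here.

Measured so far:
compound 1, `CCN1CCN(c2cc(C)c3cc(NC(=O)c4ccc[nH]4)ccc3n2)CC1`, 14700 nM
compound 2, `CCN1CCN(c2cc(C)c3cc(NC(=O)c4ccccc4F)ccc3n2)CC1`, 32600 nM
compound 3, `CCN1CCN(c2cc(C)c3cc(NC(=O)c4cccc(Br)c4)ccc3n2)CC1`, 11600 nM

All three values come from a functional assay on MCF7 cells (Homo sapiens) for antiproliferative activity, read by MTT assay, with a stated time of 72 h; a lower number here means a stronger inhibitor, a higher number a weaker inhibitor. Compound 1 stands second highest of the three numbers. Its nearest neighbour is compound 3, with a 1.3-fold lower number from compound 1 to compound 3 (0.10 log units; within the scatter), which lies within the scatter; its furthest is compound 2, with a 2.2-fold higher number from compound 1 to compound 2 (0.35 log units; beyond the scatter), a modest step beyond the scatter. Between the two phenyl amides the step is a 2.8-fold lower number from compound 2 to compound 3 (0.45 log units; beyond the scatter).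

Compound 4, `CCc1ccc(C(=O)Nc2ccc3nc(N4CCN(CC)CC4)cc(C)c3c2)cc1`, differs from compound 1 by 4-ethylphenyl in place of 1H-pyrrol-2-yl on a carbonyl carbon. Going by the values given here, the step bearing most directly on it is the one from compound 1 to compound 3, where a phenyl amide replacing the pyrrolyl amide left the number within the scatter; the step from compound 1 to compound 2 shows that a phenyl amide can also read modestly higher. Among the compounds with values here, a 4-ethylphenyl amide has no measured counterpart here, so no step beyond the scatter is expected in either direction. For compound 4 the estimate is 12000 nM, with a range of 5000 nM to 35000 nM, which is expected to correspond to a 1.2-fold lower number from compound 1 to compound 4 (0.09 log units; within the scatter).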

Compound 4, half-maximal inhibitory concentration: 3060 nM
Beside the measured number, compound 4's estimate is 3.9-fold (0.59 log units) above it, and the stated range ends above it.
By their numbers in this assay, from the lowest: compound 4; then compounds 3 and 1 (each within the scatter of the next); then compound 2.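

The group on the carbonyl carbon is not a silent position in this assay: 4-ethylphenyl in place of 1H-pyrrol-2-yl gives a 4.8-fold lower number from compound 1 to compound 4 (0.68 log units; beyond the scatter), whereas the earlier phenyl replacements either stayed within the scatter or read higher. The phenyl amides alone now span a wide range, with 4-ethylphenyl in place of 3-bromophenyl giving a 3.8-fold lower number from compound 3 to compound 4 (0.58 log units; beyond the scatter) and in place of 2-fluorophenyl giving an 11-fold lower number from compound 2 to compound 4 (1.03 log units; beyond the scatter), so a phenyl amide as such does not fix the number. No measurement at hand accounts for these steps.

The three phenyl amides differ both in the group carried and in where it sits, so these two variables cannot be separated. On these data alone, how an unsubstituted phenyl, a longer chain than ethyl, or an amine or carboxylic acid on the ring would read remains open.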